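The compounds below may be only part of what the source reports. "The series", "measured", "known", "first", "only" and "open" are said of these compounds alone.

Within the data shown here, compound 2 `CC(=O)Nc1ccc2oc(-c3ccc(C(F)(F)F)cc3)cc(=O)c2c1` gives 10000 nM in an ADME assay on THP-1 cells (Homo sapiens) for cytotoxicity, read by flow cytometry and propidium iodide staining, with a stated time of 72 h (a lower number here means a stronger inhibitor, a higher number a weaker inhibitor), the lower of the two numbers measured so far; compound 1 `COc1ccc(-c2cc(=O)c3cc(NC(C)=O)ccc3o2)cc1` gives 74000 nM. Among the measured compounds shown here, the only measured step, a 7.4-fold lower number from compound 1 to compound 2 (0.87 log units; beyond the scatter), concerns a different exchange at a different place, so it does not bear on the change that leads to compound 3 `COc1c(-c2ccc(C(F)(F)F)cc2)oc2ccc(NC(C)=O)cc2c1=O`: methoxy in place of hydrogen on an aromatic carbon. For the measured compounds named here, no comparable step is on record in this assay, so no step beyond the scatter is expected, no change at the digits printed from compound 2 to compound 3 (within the scatter). Compound 3 is accordingly estimated at 10000 nM, with a range of 4000 nM to 25000 nM.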

Compound 3, half-maximal inhibitory concentration: > 125000 nM
Compound 3 gave a limit, no number; the forecaster's own chance of this, stated with the estimate: 10%; at least 12-fold (1.09 log units) between middle value and limit.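

In this assay, methoxy in place of hydrogen on this aromatic carbon, two atoms from the ring oxygen, gives an at least 12-fold higher number from compound 2 to compound 3 (1.09 log units; beyond the scatter). For compound 3 the value > 125000 nM is a limit, not a number. Among these compounds, the earlier compounds differed at another place, so this is the first sign that this carbon tolerates no silent change: a small group here moves the number beyond the scatter.

As far as these compounds go, whether this step belongs to methoxy itself or to any group at this carbon stays open. Hydroxy, an amine or a longer alkoxy chain at this place would separate the two.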